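The compounds below may be only part of what the source reports. "The series", "measured", "known", "first", "only" and "open" are said of these compounds alone.

Measured compounds:

Compound 1, `O=C(CN1CCC(c2cccc[n+]2[O-])CC1)Nc1cccc(Cl)c1`, gives 76% in a functional assay on HEK293 cells for agonist activity at D(4) dopamine receptor (Homo sapiens), read by FLIPR; a lower number here means a smaller maximal response, a higher number a larger maximal response.
Compound 2, `Cc1cccc(NC(=O)CN2CCC(c3ccc(O)cc3)CC2)c1`, gives 60% in this assay.
Compound 3, `C=Cc1cccc(C(=O)NCN2CCC(c3cccc[n+]3[O-])CC2)c1`, gives 63% in this assay.

Among these three numbers, compound 3 holds the second highest place. Its nearest neighbour is compound 2, whose number is slightly lower, a gap that lies within the usual scatter, so the two cannot be told apart. The furthest is compound 1, whose number stands higher, a gap that is beyond the scatter.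

The next compound, compound 4, `O=C(NCN1CCC(c2cccc[n+]2[O-])CC1)c1ccccn1`, is not yet measured. It differs from compound 3 in a single place: pyridin-2-yl in place of 3-vinylphenyl on a carbonyl carbon. Going by the values given here, no measured pair in this small set shows the effect of such a change, so nothing here says which way the maximal response should move.

Given that, compound 4 is expected to remain close to compound 3, with an estimated step of a number 3 percentage points lower from compound 3 to compound 4 (within the scatter) in this assay, meaning no shift beyond the scatter in either direction. The estimate for compound 4 in this assay is therefore 60%, with a range from 45% to 78%, wide enough to cover the spread seen across the three measured compounds.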

Compound 4, largest response reached (reported as efficacy), in percent of the reference or control that the assay uses: 40%
Beside the measured number, compound 4's estimate is 20 percentage points above it, outside the stated range (below it).
By their numbers in this assay, from the lowest: compound 4; then compounds 2 and 3 (each within the scatter of the next); then compound 1.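

Going by these compounds alone, this is the first direct comparison at this position, and in this assay replacing 3-vinylphenyl with pyridin-2-yl on a carbonyl carbon gives a number 23 percentage points lower from compound 3 to compound 4 (beyond the scatter), so the group held there clearly affects the maximal response. The swap changes several things at once: the group goes from 8 heavy atoms to 6, the double bond outside the aromatic ring is lost, and a ring nitrogen enters along with one hydrogen-bond acceptor. Nothing available explains the drop or assigns it to any one of these differences.

From the compounds shown here alone, what remains open is which of these differences matters, and a plain phenyl on the same carbonyl carbon would help separate the loss of the vinyl group from the arrival of the ring nitrogen. A pyridin-3-yl group would show whether the placing of that nitrogen matters, while a 3-ethylphenyl group would test whether the double bond itself counts or whether a carbon substituent of similar size is enough.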